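A few compounds are considered here, and "the series" means these few. Any claim that something is new, unique, unknown or untested is made for them only; others in the source may bear on it.

In a functional assay on CHO cells for agonist activity at 5-hydroxytryptamine receptor 4 (Homo sapiens), read by a luciferase reporter and cAMP accumulation, with a stated time of 4 h (a lower number here means a smaller maximal response, a higher number a larger maximal response), three compounds of a shared core have been measured. Compound 1 `CC(C)c1nc(C(=O)NCC2CCN(C3CCC3)CC2)c2ccccn12` gives 20%, compound 2 `COCCCN1CCC(O)(CNC(=O)c2nc(C(C)C)n3ccccc23)CC1` gives 41%, and compound 3 `CC(C)c1nc(C(=O)NCC2(O)CCN(CC3CCOCC3)CC2)c2ccccn12` gives 34%. Compound 2 is the starting point: compound 3 lies within the usual scatter of it, so the two cannot be told apart, whereas compound 1 sits beyond the scatter with its smaller response.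

Compound 4 `CC(C)c1nc(C(=O)NCC2(O)CCN(CC(C)(C)O)CC2)c2ccccn12` has not yet been measured in this assay. It differs from compound 2 in one place: 1-hydroxy-1-methylethyl in place of 2-methoxyethyl on a saturated chain carbon bound to an amine nitrogen in a ring. The same atoms are present in both, only joined differently.

For the measured compounds named here, one measured step bears on this change. From compound 2 to compound 3 the same 2-methoxyethyl group at the same place, a saturated chain carbon bound to an amine nitrogen in a ring, was exchanged for oxan-4-yl, and the result was a number 7 percentage points lower from compound 2 to compound 3 (within the scatter). That single step suggests the group sitting at this place has little effect on the maximal response, though one step is thin evidence, and a group carrying a hydrogen-bond donor has not been tried here.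

For compound 4 no step beyond the scatter is expected, so a number 3 percentage points lower from compound 2 to compound 4 (within the scatter) is the estimated change. The maximal response of compound 4 in this assay is therefore estimated at 38%, with a likely range from 24% to 52%.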

Compound 4, largest response reached (Emax), in percent of the reference or control that the assay uses: 41%
Compound 4: the middle estimate sits 3 percentage points below what was measured; the range from low to high includes it.
By their numbers in this assay, from the lowest: compound 1; then compounds 3, 2 and 4 (each within the scatter of the next).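

In this assay putting 1-hydroxy-1-methylethyl in place of 2-methoxyethyl on a saturated chain carbon bound to an amine nitrogen in a ring gives no change at the digits printed from compound 2 to compound 4 (within the scatter) and brings in a hydrogen-bond donor where there was none, on a group with the same count of heavy atoms. Putting 1-hydroxy-1-methylethyl in place of oxan-4-yl at the same place gives a number 7 percentage points higher from compound 3 to compound 4 (within the scatter) as well, so three groups of different shape, one with a ring and one with a hydrogen-bond donor, cannot be told apart by their maximal response in these compounds. Nothing shown here gives a measured explanation for this.

Whether this tolerance extends to a carboxylic acid, a primary amine or a longer chain at this place remains open, since every group shown is neutral and carries oxygen. On these data alone, compound 1 differs from the others in more than one place, so its smaller response cannot be tied to any single group, and the part played by the hydroxyl on the ring of the other three remains unknown.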